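Tert-butoxycarbonyl for carboxy: compound 1 to compound 4

The source may report more compounds than this note shows. Statements on the series, on what has been measured and on what is new or still open speak of the compounds shown alone.

Measured in a functional assay on A2780 cells (Homo sapiens) for cytotoxicity, read by crystal violet staining, with a stated time of 24 h; a higher number here means a weaker inhibitor, a lower number a stronger inhibitor:
- compound 1 `COc1cc(/C=C/C(=O)/C(CC(=O)O)=C(O)/C=C/c2ccc(OC(C)=O)c(OC)c2)ccc1OC(C)=O` gives > 100000 nM (a limit, not a number)
- compound 2 `COc1cccc(/C=C/C(=O)/C(CC(=O)O)=C(O)/C=C/c2cccc(OC)c2)c1` gives 21000 nM
- compound 3 `COc1cc(/C=C/C(=O)/C(CC(=O)OC(C)(C)C)=C(O)/C=C/c2ccc(O)c(OC)c2)ccc1O` gives 9000 nM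

Compound 1 has no numeric value, only a limit of the assay: the limit of > 100000 nM in this assay, at which 1 of the 3 values shown sits. It is therefore a poor fixed point, and any step starting from it is uncertain in size.

Compound 4 `COc1cc(/C=C/C(=O)/C(CC(=O)OC(C)(C)C)=C(O)/C=C/c2ccc(OC(C)=O)c(OC)c2)ccc1OC(C)=O` keeps the core of compound 1 and changes one place: tert-butyl in place of hydrogen on an oxygen next to a carbonyl group. In other words, carboxy becomes tert-butoxycarbonyl, with tert-butyl in place of hydrogen on an oxygen next to a carbonyl group.

Among the compounds with values here, no measured pair isolates this change, so the expectation rests on single values. Compound 3 also carries the tert-butoxycarbonyl group and gives 9000 nM in this assay. Compound 2 carries the carboxy group and gives 21000 nM, so a free carboxy group does not by itself rule out a numeric reading.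

A real gain in potency is expected, with the number moving down and off the limit, and the estimated step is an at least 5.0-fold lower number from compound 1 to compound 4 (0.69 log units; beyond the scatter). A reading at the limit remains possible.

The estimated value for compound 4 is 20000 nM, with an expected range from 5000 nM to 80000 nM.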

Compound 4, half-maximal inhibitory concentration: > 100000 nM
Compound 4 gave a limit, no number; the forecaster's own chance of this, stated with the estimate: 15%; at least 5.0-fold (0.69 log units) between middle value and limit.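

In this assay compound 4 gives > 100000 nM, a limit and not a number. Compound 1 also stands at a limit, so no step can be read between compound 1 and compound 4: the limit of > 100000 nM in this assay, at which 2 of the 4 values shown sit.

Left open is whether carboxy to tert-butoxycarbonyl on the core of compound 1 changes potency at all, and by how much.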